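This account rests on a few compounds, and the source may have more. Where it says the series, first, only, none or still open, it means among the compounds named here.

Values in a functional assay on K562 cells (Homo sapiens) for inhibition, read by trypan blue exclusion, with a stated time of 72 h (a lower number here means a stronger inhibitor, a higher number a weaker inhibitor), so far:
compound 1 `Cn1c(=O)c(S(=O)(=O)c2ccc(F)cc2F)cc2cnc(Nc3ccc4[nH]c(C(=O)O)cc4c3)nc21` at 10000 nM
compound 2 `Cn1c(=O)c(S(=O)(=O)c2ccc(F)cc2F)cc2cnc(Nc3cccc4[nH]ccc34)nc21` at 1500 nM
compound 3 `Cn1c(=O)c(S(=O)(=O)c2ccc(F)cc2F)cc2cnc(Nc3ccc4c(c3)CC(=O)N4)nc21` at 15000 nM
compound 4 `Cn1c(=O)c(S(=O)(=O)c2ccc(F)cc2F)cc2cnc(Nc3ccccn3)nc21` not yet measured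

Compound 3 stands at the high-number end of the set, with a 1.5-fold higher number from compound 1 to compound 3 (0.18 log units; within the scatter) and a 10-fold higher number from compound 2 to compound 3 (1.00 log units; beyond the scatter) as the steps that reach it. The next change is a group of 6 heavy atoms (5 carbon, 1 nitrogen; one six-membered aromatic ring with 1 hetero atom) in place of a group of 10 heavy atoms (8 carbon, 1 nitrogen, 1 oxygen; one five-membered non-aromatic ring with 1 hetero atom, one six-membered aromatic ring of carbon only), on a nitrogen on an aromatic ring and it falls at the same place as every measured step. Besides those two, the only other step is a 6.7-fold lower number from compound 1 to compound 2 (0.82 log units; beyond the scatter) and none of the three brings in pyridin-2-yl, so they bound the size only. With compound 3 at 15000 nM near the top of this narrow range, a modest move to a lower number is expected. The expected step is a 3.0-fold lower number from compound 3 to compound 4 (0.48 log units; beyond the scatter) on this estimate. Compound 4 is estimated at 5000 nM (expected range 1500 nM to 15000 nM).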

Compound 4, half-maximal inhibitory concentration: 35000 nM
Estimate against measurement, compound 4: 7.0-fold (0.85 log units) below, and the stated range ends below it.
By their numbers in this assay, from the lowest: compound 2; then compounds 1 and 3 (each within the scatter of the next); then compound 4.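

In this assay pyridin-2-yl on this nitrogen gives the highest number of the set, with a 2.3-fold higher number from compound 3 to compound 4 (0.37 log units; beyond the scatter) and a 3.5-fold higher number from compound 1 to compound 4 (0.54 log units; beyond the scatter) as modest steps and a 23-fold higher number from compound 2 to compound 4 (1.37 log units; beyond the scatter) as the large one. Compound 4, the only one here with a single ring in this group, falls short of all three two-ring groups, so a single ring with 1 hetero atom does not improve on them. No measurement on hand accounts for this loss.

Open, going by these compounds, is whether phenyl, or pyridin-2-yl carrying an aminomethyl chain, would reach the level of compound 2 at 1500 nM in this assay.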